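Aryl amide swap in a hydroxamic acid series

The source may hold more compounds than are shown below. What is called first, only, known or untested is meant among the compounds shown, and "the series" means these compounds.

Measured compounds:
compound 1 `CN(C)c1ccc(C(=O)N(CCCCCC(=O)NO)CC(=O)NC2CCCCC2)cc1` — 2970 nM
compound 2 `CCCCNC(=O)CN(CCCCCC(=O)NO)C(=O)c1ccc(N(C)C)cc1` — 1870 nM
compound 3 `Cc1ccc(NC(=O)CN(CCCCCC(=O)NO)C(=O)c2cc(C)cc(C)c2)cc1` — 1670 nM

In a functional assay on CAL-27 cells (Homo sapiens) for cytotoxicity, read by MTT assay, with a stated time of 72 h (a higher number here means a weaker inhibitor, a lower number a stronger inhibitor), compound 1 gives 2970 nM, the highest number of the three measured, though compound 2 and compound 3 both lie within the scatter of it. Going by the values given here, the single one-place step recorded, a 1.6-fold lower number from compound 1 to compound 2 (0.20 log units; within the scatter), concerns butyl in place of cyclohexyl on an amide-type nitrogen and falls within the scatter. Among the compounds with values here, compound 3 differs from the others in more than one place, so no step is drawn from it.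

Compound 4 `O=C(CCCCCN(CC(=O)NC1CCCCC1)C(=O)c1cccc2ccccc12)NO` is not yet measured. It differs from compound 1 by naphthalen-1-yl in place of 4-(dimethylamino)phenyl on a carbonyl carbon. Within the data shown here, no measured step touches the carbonyl carbon that carries the aromatic group, so nothing here bears directly on this change. Among the measured compounds shown here, the three numbers in this assay sit close together, and the one recorded step is within the scatter; on that basis the step of a 1.2-fold lower number from compound 1 to compound 4 (0.07 log units; within the scatter) is expected to be small, with no confident direction. Compound 4 is estimated at 2500 nM, between 1100 nM and 5800 nM.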

Compound 4, half-maximal inhibitory concentration: 2400 nM
Beside the measured number, compound 4's estimate is 1.0-fold (0.02 log units) above it; the measured number falls inside the stated range.
By their numbers in this assay, from the lowest: compounds 3, 2, 4 and 1 (each within the scatter of the next).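

Naphthalen-1-yl in place of 4-(dimethylamino)phenyl on a carbonyl carbon gives, in this assay, a 1.2-fold lower number from compound 1 to compound 4 (0.09 log units; within the scatter), the first reading at this position. Within this one pair, the group with two six-membered aromatic rings of carbon only and no nitrogen stands level with the group carrying the dimethylamino nitrogen, so that nitrogen is not required to hold the number in this assay. No supporting data bear on why the swap leaves the number within the scatter.

Still open, on these data alone, is whether a carboxylic acid or an amine on the aromatic group, or a pyridine ring in its place, would move the number beyond the scatter. Also open, as far as these compounds go, is whether the same swap behaves alike with butyl in place of cyclohexyl, or with a longer chain carrying the hydroxamic acid.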